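Swapping the pyridine for thiophene at the core of compound 1

This account rests on a few compounds, and the source may have more. Where it says the series, first, only, none or still open, it means among the compounds named here.

Within the data shown here, compound 1 `Oc1ccc(-c2cc(-c3cccc(Cl)c3)nc(-c3ccccn3)c2)cc1` is one of three compounds measured in an ADME assay on HEK293 cells (Homo sapiens) for cytotoxicity, read by CCK-8 assay and cell counting, with a stated time of 2 days (a lower number here means a stronger inhibitor, a higher number a weaker inhibitor), where compound 1 gives 25400 nM, the highest of the three numbers. Compound 2 `Oc1cccc(-c2cc(-c3ccc(Cl)cc3)nc(-c3cccs3)c2)c1` gives 11800 nM and compound 3 `Oc1cccc(-c2cc(-c3ccc(Cl)cc3)nc(-c3ccco3)c2)c1` gives 8190 nM; compound 1 stands beyond the scatter above both, closest to compound 2 and furthest from compound 3. Among the measured compounds shown here, the only single-point step among the measured compounds is a 1.4-fold lower number from compound 2 to compound 3 (0.16 log units; within the scatter).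

Compound 4 `Oc1ccc(-c2cc(-c3ccsc3)nc(-c3cccc(Cl)c3)c2)cc1` arises from compound 1 by a single change: thiophen-3-yl in place of pyridin-2-yl on an aromatic carbon. For the measured compounds named here, no measured step covers this exact exchange. Compounds 2 and 3 both carry a five-membered heteroaryl group at the corresponding place and give lower numbers than the pyridin-2-yl compound 1, but they also differ from compound 1 elsewhere, so their values bear on the step only loosely. The step from compound 2 to compound 3 shows that trading one five-membered heteroaryl group for another changed little.

On that basis, compound 4 is expected to fall modestly below compound 1, a step of a 1.7-fold lower number from compound 1 to compound 4 (0.23 log units; within the scatter), with compound 4 estimated at 15000 nM within a range of 6000 nM to 40000 nM.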

Compound 4, half-maximal inhibitory concentration: 2670 nM
The estimate for compound 4 lay 5.6-fold (0.75 log units) above the measured number, outside the stated range (below it).
By their numbers in this assay, from the lowest: compound 4; then compounds 3 and 2 (each within the scatter of the next); then compound 1.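

In this assay, the place next to the ring nitrogen proves sensitive to this exchange: thiophen-3-yl in place of pyridin-2-yl gives a 9.5-fold lower number from compound 1 to compound 4 (0.98 log units; beyond the scatter), a step beyond the scatter. The earlier compounds shown here offered only a 1.4-fold lower number from compound 2 to compound 3 (0.16 log units; within the scatter), a step within the scatter between two five-membered heteroaryl groups, and so gave no direct reading of what happens when the six-membered pyridin-2-yl group leaves this place on the core of compound 1. Nothing available explains the size of the step from compound 1 to compound 4.

The exchange changes the ring size and the hetero atom together, so these compounds do not separate the contribution of the five-membered ring from that of sulfur replacing nitrogen. They also leave open how this place would respond to a plain phenyl group, an amine or a carboxylic acid, and whether a thiophen-2-yl or furan-2-yl group would give a similar step when carried on the core of compound 1.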